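This account rests on a few compounds, and the source may have more. Where it says the series, first, only, none or still open, it means among the compounds named here.

Going by the values given here, in a physicochemical assay for solubility, read by HPLC, using the shake flask method, measured as kinetic solubility, with a stated time of 2 h, at pH 7.4 (on this read-out higher numbers stand for higher solubility and lower numbers for lower solubility), compound 2 `Cc1cc(NCc2ccccn2)n2nc(C)c(Nc3ccccc3)c2n1` gives 7800 nM, the only full number among the values shown. Compound 1 `Cc1cc(NCc2ccccn2)n2nc(C)c(-c3ccc(F)cc3)c2n1` reaches only a limit in this assay, namely < 5000 nM; this is the limit of < 5000 nM in this assay, at which 1 of the 2 values shown sits. The step of an at least 1.5-fold higher number from compound 1 to compound 2 (0.19 log units; that floor lies within the scatter) is the only measured one. Compound 3 `Cc1cc(NCc2ccccn2)n2nc(C)cc2n1` has not yet been measured; it differs from compound 2 by hydrogen in place of anilino on an aromatic carbon. Among the compounds with values here, no measured step removes this group outright, so the step from compound 1 to compound 2, which swapped one group for another at the same aromatic carbon, is the only guide, and it points to a modestly higher number. Compound 3 is therefore expected to show a higher number, by a 1.9-fold higher number from compound 2 to compound 3 (0.28 log units; within the scatter). The estimate for compound 3 in this assay is 15000 nM, with a range from 5000 nM to 45000 nM.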

Compound 3, solubility: > 200000 nM
Compound 3 gave a limit, no number; the forecaster's own chance of this, stated with the estimate: 10%; at least 13-fold (1.12 log units) between middle value and limit.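

With hydrogen in place of anilino on this aromatic carbon, this assay shows an at least 25-fold higher number from compound 2 to compound 3 (1.40 log units; beyond the scatter), and with hydrogen in place of 4-fluorophenyl it shows an at least 40-fold higher number from compound 1 to compound 3 (1.60 log units; beyond the scatter). Both steps lie beyond the scatter, whereas the swap of one ring-bearing group for the other gave an at least 1.5-fold higher number from compound 1 to compound 2 (0.19 log units; that floor lies within the scatter), so among these three compounds, having a six-membered aromatic ring at this carbon at all counts for more than which of the two groups carries it. Compound 3 stands at a limit and not at a number, so both new steps give only a minimum size: the limit of > 200000 nM in this assay, at which 1 of the 3 values shown sits.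

The compounds shown leave open how the read-out responds to a small group on this carbon, such as an amine, a hydroxyl or a nitrile. They also leave open whether the number falls gradually as the group grows or only once a ring is attached.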